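The source may hold more compounds than are shown below. What is called first, only, known or untested is meant among the compounds shown, and "the series" means these compounds.

Of the compounds shown here, two built on the same core have been measured in a functional assay on HeLa cells (Homo sapiens) for cytotoxicity, read by MTT assay, with a stated time of 72 h; a higher number here means a weaker inhibitor, a lower number a stronger inhibitor. Compound 1 `Cc1ccc(C)c(N2CCN(Cc3nnc(-c4cc(S(N)(=O)=O)c(SCc5ccccc5)cc4Cl)o3)CC2)c1` gives 16000 nM in this assay. Compound 2 `NC(=O)c1cn(Cc2nnc(-c3cc(S(N)(=O)=O)c(SCc4ccccc4)cc3Cl)o2)nn1` gives 75000 nM in this assay. Compound 2 therefore has the highest number of the two, meaning it is the weaker inhibitor, and its gap from compound 1 is larger than the usual scatter of repeated measurements.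

Compound 3 `NS(=O)(=O)c1cc(-c2nnc(/C=C/c3c(Cl)cccc3Cl)o2)c(Cl)cc1SCc1ccccc1` has not yet been measured. It differs from compound 2 in one place: 2-(2,6-dichlorophenyl)ethenyl in place of (4-carbamoyl-1H-1,2,3-triazol-1-yl)methyl on an aromatic carbon. Within the data shown here, no measured pair differs in exactly this way, so the size of the step has to be estimated rather than read from the data. Because compound 1 gives 16000 nM with a different group at that place, the core is known to accept other groups there, and the number for compound 3 is expected to land lower than that of compound 2 rather than higher. Compound 3 is expected to give about 15000 nM in this assay, with a plausible range from 4000 nM to 60000 nM. The expected step of a 5.0-fold lower number from compound 2 to compound 3 (0.70 log units; beyond the scatter) is a moderate one, beyond the scatter, toward a stronger inhibitor.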

Compound 3, half-maximal inhibitory concentration: 12000 nM
Compound 3: the middle estimate sits 1.3-fold (0.10 log units) above what was measured; measured number inside the range.
By their numbers in this assay, from the lowest: compounds 3 and 1 (each within the scatter of the next); then compound 2.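

In this assay, exchanging the group on this aromatic carbon gives a 6.3-fold lower number from compound 2 to compound 3 (0.80 log units; beyond the scatter), so this position responds to what is placed on it, and here a group with no hydrogen-bond donors or acceptors replaces one that has both without any loss of strength. Compound 3 and compound 1 lie within the scatter of each other, so these two very different groups cannot be told apart in this assay, while compound 2, with its (4-carbamoyl-1H-1,2,3-triazol-1-yl)methyl group, stands apart from both. Among these compounds, nothing measured so far explains the step, so the reason for it remains unknown.

The change replaces the whole group at once, so the contributions of the two chlorines, the ethenyl link and the departing carbamoyl cannot be weighed separately. A plain 2-phenylethenyl group without the chlorines, or a carboxylic acid in place of the carbamoyl on the triazole, would help to pull these contributions apart.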